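The compounds below may be only part of what the source reports. "The series", "measured", "known", "first", "only" and "open" are said of these compounds alone.

Compound 1 `CC(C)[C@H](NC(=O)COc1cccc2ccccc12)C(=O)N[C@@H](CC(=O)O)C(=O)CSc1nnnn1C` carries a (1-methyl-1H-tetrazol-5-yl)sulfanyl group on a saturated chain carbon bound to a carbonyl carbon. In a functional assay on Jurkat cells (Homo sapiens) for inhibition (on this read-out higher numbers stand for weaker inhibition and lower numbers for stronger inhibition), compound 1 gives only a limit of the assay, > 200000 nM, and so stands at the edge of what was measured (the limit of > 200000 nM in this assay, at which 1 of the 2 values shown sits). Compound 2 `CC(C)[C@H](NC(=O)COc1cccc2ccccc12)C(=O)N[C@@H](CC(=O)O)C(=O)COc1cncc2ccccc12`, which bears (isoquinolin-4-yl)oxy at the same place, is measured in this assay at 166000 nM. The step of an at least 1.2-fold lower number from compound 1 to compound 2 (0.08 log units; that floor lies within the scatter) does not leave the scatter. Compound 3 `CC(C)[C@H](NC(=O)COc1cccc2ccccc12)C(=O)N[C@@H](CC(=O)O)C(=O)COc1nccc2ccccc12` has not yet been measured; it differs from compound 1 in that ((isoquinolin-1-yl)oxy in place of (1-methyl-1H-tetrazol-5-yl)sulfanyl on a saturated chain carbon bound to a carbonyl carbon). Going by the values given here, this change resembles the one from compound 1 to compound 2, the only measured step that bears on it, and that step was small. For compound 3 the estimated step is therefore an at least 1.2-fold lower number from compound 1 to compound 3 (0.09 log units; that floor lies within the scatter). Compound 3 is expected to give about 160000 nM in this assay, within a range from 70000 nM to 300000 nM.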

Compound 3, half-maximal inhibitory concentration: 106000 nM
Beside the measured number, compound 3's estimate is 1.5-fold (0.18 log units) above it; the range from low to high includes it.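

In this assay, putting isoquinolin-1-yl in place of isoquinolin-4-yl on the oxygen gives a 1.6-fold lower number from compound 2 to compound 3 (0.19 log units; within the scatter), so the point of attachment of the isoquinoline ring makes no readable difference between these two compounds. Exchanging (1-methyl-1H-tetrazol-5-yl)sulfanyl for (isoquinolin-1-yl)oxy gives an at least 1.8-fold lower number from compound 1 to compound 3 (0.27 log units; that floor lies within the scatter), so this second isoquinoline group also shows no change beyond the scatter, although the true step could be larger. Compound 1 gives only a limit of the assay, so this step can be read only as a floor: the limit of > 200000 nM in this assay, at which 1 of the 3 values shown sits.

On these data alone, it remains open whether a different group at this place, such as phenoxy or an amine, would move the number beyond the scatter. As far as these compounds go, it also remains open how the carboxylic acid shared by all three compounds compares with its methyl ester.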